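This account rests on a few compounds, and the source may have more. Where it says the series, first, only, none or still open, it means among the compounds named here.

Working notes on the series. Three compounds have been run in a functional assay on SK-MEL-2 cells (Homo sapiens) for cytotoxicity, read by sulforhodamine B assay, with a stated time of 48 h (a higher number here means that more compound is tolerated, a lower number that less compound is tolerated), so far. Compound 1 `ClCc1cccc(Cn2cnc3ncnc(Cl)c32)c1` gives 6760 nM in this assay. Compound 2 `ClCc1ccc(Cn2cnc3nc(Cl)nc(Cl)c32)cc1` gives 6450 nM in this assay. Compound 3 `ClCc1cccc(Cn2cnc3c(Cl)nc(Cl)nc32)c1` gives 10000 nM in this assay. Compound 2 sits with compound 1 and compound 3 in a narrow band: its gap to compound 1 is negligible, and its gap to compound 3 also lies within the scatter, so the three numbers cannot be told apart on the data in hand. Within the data shown here, no pair among them differs in only one place, so no single step has been quantified.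

The next compound, compound 4 `ClCc1ccc(Cn2cnc3ncnc(Cl)c32)cc1`, is compound 2 with one alteration: hydrogen in place of chloro on an aromatic carbon. This removes one chlorine from the six-membered aromatic ring with two nitrogen atoms in the shared core, between two ring nitrogen atoms, leaving the other chloro group and the chloromethyl arm on the benzyl group unchanged.

Among the measured compounds shown here, with no measured single-point step to lean on, and with compound 1, compound 2 and compound 3 all sitting within the scatter of one another in this assay, the expected step from compound 2 to compound 4 is a 1.0-fold higher number from compound 2 to compound 4 (0.00 log units; within the scatter), with no shift beyond the scatter anticipated in either direction. Compound 4 is accordingly estimated at 6500 nM in this assay, with a range from 3000 nM to 14000 nM.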

Compound 4, concentration lethal to 50% of the cells: > 100000 nM
Compound 4 was reported as a limit (the forecaster's own chance of this, stated with the estimate: 10%); middle value at least 15-fold (1.18 log units) from the limit.
By their numbers in this assay, from the lowest: compounds 2, 1 and 3 (each within the scatter of the next). At a limit, above all of these: compound 4.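

In this assay, among these compounds, this is the first single-place step: hydrogen in place of chloro on the aromatic carbon between two ring nitrogen atoms gives an at least 15-fold higher number from compound 2 to compound 4 (1.19 log units; beyond the scatter), so this position carries a large change where the earlier compounds offered only a narrow band of numbers. Compound 4 is reported only as a limit in this assay, so the step has a floor but no fixed size: the limit of > 100000 nM in this assay, at which 1 of the 4 values shown sits. The change does not stand alone, since compound 1 also lacks this chloro group and differs from compound 4 only in where the chloromethyl arm sits on the benzyl group. In this assay compound 1 gives 6760 nM, which points to the arm's placement as a second factor in the outcome.

The compounds shown leave open whether chloro is the only group at this position that keeps the number near that of compound 2, since an amine, a methoxy group or a methyl group there would test this. They also leave open whether the same step would appear with a longer chain or a hydroxymethyl group in place of the chloromethyl arm on the benzyl group.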